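A few compounds are considered here, and "the series" means these few. Any claim that something is new, unique, unknown or untested is made for them only; others in the source may bear on it.

Measured so far:
- Compound 1, `O=C(NCCCCc1ccccc1)Oc1cccc(-c2ccccc2)c1`: 0.11 h
- Compound 2, `O=C(NCCCCCCc1ccccc1)Oc1cccc(-c2ccccc2)c1`: 0.14 h
- Compound 3, `O=C(NCc1ccc2ccccc2c1)Oc1cccc(-c2ccccc2)c1`: 0.0167 h

In an ADME assay on a cell-free system (plasma, Rattus norvegicus, strain Wistar) for metabolic stability, read by HPLC, tested at 1 uM (a lower number here means that the compound disappears faster, a higher number that the compound lasts longer), compound 2 gives the highest of the three numbers. Its neighbour is compound 1, and the step of a 1.3-fold higher number from compound 1 to compound 2 (0.10 log units; within the scatter) is small. Compound 3 sits far lower; compound 3 gives 0.0167 h, which is well beyond the scatter from compound 2.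

Compound 4, `CCCCNC(=O)Oc1cccc(-c2ccccc2)c1`, has not yet been measured. It differs from compound 2 by hydrogen in place of phenethyl on a saturated chain carbon, four bonds along the chain from an amide-type nitrogen. Within the data shown here, the only measured step that touches this same place on the chain is a 1.3-fold higher number from compound 1 to compound 2 (0.10 log units; within the scatter), and it stayed within the scatter, though it only exchanged one aromatic group for another rather than removing it. On that slim basis the expected step of a 1.4-fold lower number from compound 2 to compound 4 (0.15 log units; within the scatter) is modest, leaning slightly lower. Compound 4 is therefore estimated at 0.1 h, with a range from 0.04 h to 0.3 h.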

Compound 4, half-life in the plasma assay: 0.36 h
Beside the measured number, compound 4's estimate is 3.6-fold (0.56 log units) below it, and the stated range ends below it.
By their numbers in the plasma assay, from the lowest: compound 3; then compounds 1 and 2 (each within the scatter of the next); then compound 4.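

In the plasma assay, removing the aromatic ring from the chain has a clear effect, as a 2.6-fold higher number from compound 2 to compound 4 (0.41 log units; beyond the scatter) and a 3.3-fold higher number from compound 1 to compound 4 (0.51 log units; beyond the scatter) show, whereas changing the chain between the two ring-bearing compounds did not. In a physicochemical assay, read by HPLC, in phosphate buffer, at pH 7.0 (a lower number here means that less of the compound is left, a higher number that more of the compound is left), compound 2 gives 61.1% and compound 4 gives 46.7%, so the same change moves these two read-outs in opposite directions.

Chain length and the ring change together here, so their separate contributions remain open. So does how an amine or a carboxylic acid at this place would behave.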